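Ring swap on compound 2 toward compound 3

The source may hold more compounds than are shown below. What is called first, only, known or untested is meant among the compounds shown, and "the series" means these compounds.

The series shares the core of compound 1 `S=c1[nH]nc(-c2ccccc2Sc2ccccc2)o1`. In a functional assay on the whole organism (strain NMRI) for inhibition, with Mus musculus as the target, in the formalin test, with a stated time of 30 min, at a dose of 30 umol/kg by the intraperitoneal route (a higher number here means more inhibition at the dose given (going by the name of the read-out), a lower number less inhibition), compound 1 gives 13.1%. Compound 2 `Nc1nnc(-c2ccccc2Sc2ccccc2)o1` carries the 5-amino-1,3,4-oxadiazol-2-yl group on the same core, and in this assay compound 2 gives 16.6%. Compound 2 and compound 1 stand within the scatter of each other: a number 3.5 percentage points higher from compound 1 to compound 2 (within the scatter). Compound 3 `S=c1[nH]nc(-c2ccccc2Sc2ccccc2)[nH]1` is the unmeasured member; the change from compound 2 is a group of 6 heavy atoms (2 carbon, 3 nitrogen, 1 sulfur; one five-membered aromatic ring with 3 hetero atoms) in place of a group of 6 heavy atoms (2 carbon, 3 nitrogen, 1 oxygen; one five-membered aromatic ring with 3 hetero atoms), on an aromatic carbon. For the measured compounds named here, the one measured step, a number 3.5 percentage points higher from compound 1 to compound 2 (within the scatter), is the only guide, and it stayed within the scatter when a group at this position was exchanged. The entering group of compound 3, like the group on compound 1, contains sulfur and a double bond outside the aromatic ring, so no shift beyond the scatter is expected. Compound 3 is therefore estimated at 15%, with a range from 5% to 27%. The expected step is a number 1.6 percentage points lower from compound 2 to compound 3 (within the scatter).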

Compound 3, a percentage reported as inhibition, in the whole organism at one dose (the size of the read-out at that dose, not a potency): 49.4%
Compound 3: middle estimate off by 34.4 percentage points, on the low side; measured number above the stated range.
By their numbers in this assay, from the lowest: compounds 1 and 2 (each within the scatter of the next); then compound 3.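

In this assay, for the compounds shown here, this position proves sensitive to which five-membered aromatic ring with 3 hetero atoms it carries, with a number 32.8 percentage points higher from compound 2 to compound 3 (beyond the scatter) as the first step beyond the scatter. Sulfur and a double bond outside the aromatic ring do not suffice on their own: compound 1 also has both, yet a number 36.3 percentage points higher from compound 1 to compound 3 (beyond the scatter), a change that leaves the ring with 3 nitrogen atoms and no oxygen. Nothing measured on these groups explains the gain.

Going by these compounds, whether an amine or a methylthio group in place of the sulfur of compound 3 would hold this level stays open, as does the effect of a methyl group on a ring nitrogen. The data also leave open whether the gain persists at other doses or times.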